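A few compounds are considered here, and "the series" means these few. Any claim that something is new, unique, unknown or untested is made for them only; others in the source may bear on it.

Measured in a functional assay on BXPC-3 cells (Homo sapiens) for inhibition, read by XTT assay, with a stated time of 72 h; on this read-out lower numbers stand for stronger inhibition and higher numbers for weaker inhibition:
- compound 1 `C=CCCCCCCCCCOC[C@@H]1CCCN1C(=O)OC(C)(C)C`: 50000 nM
- compound 2 `CCCCCCCC/C=C\CCCCCCCCOC[C@@H]1CCCN1C(=O)OC(C)(C)C`: > 100000 nM (a limit)
- compound 3 `CCCCCCCC/C=C/CCCCCCCCOC[C@@H]1CCCN1C(=O)OC(C)(C)C`: > 100000 nM (a limit)

Compound 2 stands at > 100000 nM, which is a limit of the assay and not a number.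

Compound 4 `CCCCCCCC/C=C\CCCCCCCCOC[C@@H]1CCCN1C(=O)[C@@H]1CCCN1C(=O)OC(C)(C)C` carries one change from compound 2 : 1-(tert-butoxycarbonyl)pyrrolidin-2-yl in place of tert-butoxy on a carbonyl carbon. In words, 1-(tert-butoxycarbonyl)pyrrolidin-2-yl replaces tert-butoxy on a carbonyl carbon.

Within the data shown here, no measured step touches this carbonyl carbon, since all three change the chain. They are an at least 2.0-fold higher number from compound 1 to compound 2 (0.30 log units; that floor lies within the scatter) and an at least 2.0-fold higher number from compound 1 to compound 3 (0.30 log units; that floor lies within the scatter), neither of which gets past the scatter, and a step that the two limits leave unreadable from compound 2 to compound 3, which cannot be sized.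

The series therefore gives no basis for a size or a direction, and no step beyond the scatter is expected in this assay. The expected result is a number no higher from compound 2 to compound 4 (the limit leaves the size open), and a report of only a limit is the likeliest outcome.

Compound 4 is estimated at 100000 nM, with an expected range of 40000 nM to 250000 nM.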

Compound 4, half-maximal inhibitory concentration: > 100000 nM
Compound 4: only a limit was reported; the forecaster's own chance of this, stated with the estimate: 65%; the middle value sits exactly at the limit.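

In this assay compound 4 gives > 100000 nM, a limit of the assay and not a number. Compound 2 also stands at a limit, and no step can be read between compound 2 and compound 4. The compounds shown leave open whether 1-(tert-butoxycarbonyl)pyrrolidin-2-yl in place of tert-butoxy changes inhibition at all.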